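The source may hold more compounds than are shown below. What is called first, only, known or untested is meant among the compounds shown, and "the series" means these compounds.

Measured in an ADME assay on NIH3T3 cells (Mus musculus) for cytotoxicity, read by MTT assay, with a stated time of 48 h; a lower number here means that less compound is tolerated, a higher number that more compound is tolerated:
- compound 1 `COc1ccc(/C=C/C(=O)c2ccc(OC)c(S(N)(=O)=O)c2)cc1`: 96000 nM
- compound 2 `COc1ccc(C(=O)/C=C/c2ccccc2)cc1S(=O)(=O)Nc1c(N)nc(SC)[nH]c1=O`: 17000 nM
- compound 3 `COc1ccc(C(=O)/C=C/c2ccc(C)cc2)cc1S(=O)(=O)Nc1c(N)nc(SC)[nH]c1=O`: 7200 nM

Of these three, compound 3 has the lowest number, at 7200 nM. Compound 4 `COc1ccc(/C=C/C(=O)c2ccc(OC)c(S(=O)(=O)Nc3c(N)nc(SC)[nH]c3=O)c2)cc1` differs from it as follows: methoxy in place of methyl on an aromatic carbon. In words, methoxy stands in place of methyl on an aromatic carbon, para to a large group. Going by the values given here, only one measured step bears on this site: a 2.4-fold lower number from compound 2 to compound 3 (0.37 log units; beyond the scatter), a modest change on swapping hydrogen for methyl. Among the compounds with values here, compound 1 also carries the 4-methoxyphenyl but differs from compound 4 elsewhere, so it offers no direct step. A similarly modest change or less is therefore expected, perhaps within the scatter, with a slightly higher number the likelier direction. The expected step is a 1.3-fold higher number from compound 3 to compound 4 (0.10 log units; within the scatter). Compound 4 is estimated at 9000 nM, with an expected range of 3500 nM to 23000 nM.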

Compound 4, concentration lethal to 50% of the cells: 6500 nM
The estimate for compound 4 lay 1.4-fold (0.14 log units) above the measured number, and the stated range covers the measured number.
By their numbers in this assay, from the lowest: compounds 4 and 3 (each within the scatter of the next); then compound 2; then compound 1.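

In this assay the step of a 1.1-fold lower number from compound 3 to compound 4 (0.04 log units; within the scatter) shows that methoxy and methyl at this site cannot be told apart. Measured against hydrogen, methoxy gives a 2.6-fold lower number from compound 2 to compound 4 (0.42 log units; beyond the scatter) and so stands beyond the scatter, as methyl did. With the 4-methoxyphenyl common to both, the large group on the sulfonamide nitrogen gives a 15-fold lower number from compound 1 to compound 4 (1.17 log units; beyond the scatter) and remains the biggest step in the set. Nothing at hand offers an explanation for these numbers. From the compounds shown here alone, whether an amine or a carboxylic acid on this aromatic carbon would depart from methyl and methoxy stays open.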